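A few compounds are considered here, and "the series" means these few. Any claim that something is new, unique, unknown or untested is made for them only; others in the source may bear on it.

Going by the values given here, only two compounds with the same core have been tested so far in an ADME assay on MDBK cells (Bos taurus) for cytotoxicity; on this read-out lower numbers stand for higher toxicity in this test and higher numbers for lower toxicity in this test. Compound 1 `Clc1cccc(Cn2ccc3nc(-c4ccccc4)nc-3c2)c1` returned > 100000 nM, which is a limit of the assay and not a number. Among the compounds with values here, compound 2 `Brc1ccc(Cn2ccc3nc(-c4ccccc4)nc-3c2)cc1` gave 83000 nM, the only true number so far, and the other result is the limit of > 100000 nM in this assay, at which 1 of the 2 values shown sits.

Compound 3 `N#Cc1cccc(Cn2ccc3nc(-c4ccccc4)nc-3c2)c1` keeps the core of compound 2 and changes one group: 3-cyanophenyl in place of 4-bromophenyl on a saturated chain carbon bound to an aromatic nitrogen. In short, it carries 3-cyanophenyl in place of 4-bromophenyl on a saturated chain carbon bound to an aromatic nitrogen.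

Within the data shown here, one measured step bears on this, since it changes the group at the same place. That step is an at least 1.2-fold lower number from compound 1 to compound 2 (0.08 log units; that floor lies within the scatter), with 4-bromophenyl in place of 3-chlorophenyl. On these data alone, its true size stays unknown, as one end of it is a limit, but it offers no sign of a large effect from swapping this group. On that slim evidence, the expected change is small, with a 1.1-fold higher number from compound 2 to compound 3 (0.04 log units; within the scatter) estimated to stay within the scatter, and a result at the limit of this assay is also quite possible. For compound 3 the expected value is 90000 nM, with an estimated range from 40000 nM to 180000 nM.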

Compound 3, half-maximal cytotoxic concentration: > 100000 nM
Compound 3 ended at the assay's limit (the forecaster's own chance of this, stated with the estimate: 45%); middle value at least 1.1-fold (0.04 log units) from the limit.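

In this assay, on these data alone, the change to 3-cyanophenyl gives an at least 1.2-fold higher number from compound 2 to compound 3 (0.08 log units; that floor lies within the scatter), and its true size stays unknown, as one end of the step is a limit. The step from compound 1 to compound 3 cannot be read, as both of its ends are limits. What compound 3 adds is a third group at this place, one with a nitrile and a hydrogen-bond acceptor that 4-bromophenyl lacks, and it too leaves no sign of a large effect, though most of these results are limits and not numbers: the limit of > 100000 nM in this assay, at which 2 of the 3 values shown sit.

The true values of compound 1 and compound 3 stay unknown, so any real difference among these three groups could remain hidden. As far as these compounds go, it also remains open whether an amine or a carboxylic acid on this phenyl ring, or a longer chain between the ring and the aromatic nitrogen, would bring the number down in this assay.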